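A few compounds are considered here, and "the series" means these few. Any claim that something is new, unique, unknown or untested is made for them only; others in the source may bear on it.

Compound 1 `COc1ccc(OC)c(-c2nc(C(c3ccccc3)c3ccccc3)sc2CC(=O)O)c1` is measured in an in vitro functional assay on HEK285-7 cells for antagonist activity at prostaglandin D2 receptor 2 (Homo sapiens), read by BRET and beta-arrestin recruitment; a lower number here means a smaller maximal response, a higher number a larger maximal response. In that assay compound 1 gives 80%. Compound 2 `O=C(O)Cc1sc(C(c2ccc(F)cc2)c2ccc(F)cc2)nc1-c1ccc(Cl)cc1` gives 80%, the same number at the digits shown, so the two sit together within the scatter of this assay, and no order between them can be read. Compound 3 `O=C(O)Cc1sc(C2COc3ccccc3O2)nc1-c1ccc(Cl)cc1` gives 50%, a clearly lower number, beyond the scatter. Compound 1 therefore stands, together with compound 2, at the larger end of the three maximal responses measured so far.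

Compound 4 `O=C(O)Cc1sc(C(c2ccccc2)c2ccccc2)nc1-c1ccccc1` differs from compound 1 in a single place: phenyl in place of 2,5-dimethoxyphenyl on an aromatic carbon. Among the measured compounds shown here, no single-point step between two measured compounds has been recorded, so the size of this step has to be judged from what the three values show. Compound 1 and compound 2 carry different aryl groups on that aromatic carbon and give the same number, which suggests that the aryl group there does little to the maximal response. Compound 4 is therefore expected to give 75%, with a likely range from 55% to 95%. The step that this estimate means, a number 5 percentage points lower from compound 1 to compound 4 (within the scatter), is expected to stay within the scatter, in no clear direction.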

Compound 4, largest response reached (reported as efficacy), in percent of the reference or control that the assay uses: 80%
The estimate for compound 4 lay 5 percentage points below the measured number; low and high end bracket the measured number.
By their numbers in this assay, from the lowest: compound 3; then compounds 1, 2 and 4 (each within the scatter of the next).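

Replacing 2,5-dimethoxyphenyl with phenyl on this aromatic carbon, next to the ring nitrogen, gives no change at the digits printed from compound 1 to compound 4 (within the scatter) in this assay. Among the compounds shown here, the earlier compounds differ from one another in more than one place, so this is the first change at this position that can be read on its own. The 2 hydrogen-bond acceptors of the leaving group are gone in phenyl, and this read-out does not separate the two compounds.

The compounds shown leave open whether an amine or a nitrile on this aromatic carbon, in place of an aryl ring, would give a similar maximal response. Going by these compounds, this step also rests on a single pair, so it remains unknown whether it would hold with a different large group on the core. No measurement at hand explains the result.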